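The source may report more compounds than this note shows. Statements on the series, on what has been measured and on what is new or still open speak of the compounds shown alone.

Measured so far:
compound 1, `C[S+]([O-])c1ccccc1-c1ncc(C(=O)O)c(=O)[nH]1`: > 5 mg/kg
compound 2, `CCOc1ccc(Cl)cc1-c1ncc(C(=O)O)c(=O)[nH]1`: 0.5 mg/kg

Within the data shown here, in a functional assay on the whole organism (strain Sprague-Dawley) for inhibition, with Rattus norvegicus as the target, with a stated time of 10 min (a lower number here means that less compound is needed, a higher number that more compound is needed for the effect), compound 2 gives 0.5 mg/kg, the only plain number among the two values shown. For compound 1 this assay reports (the limit of > 5 mg/kg in this assay, at which 1 of the 2 values shown sits), a limit and not a number.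

Compound 3, `CCOc1ccc(S(=O)(=O)N(C)C(C)C)cc1-c1ncc(C(=O)O)c(=O)[nH]1`, is not yet measured. The change from compound 2 is isopropyl(methyl)sulfamoyl in place of chloro on an aromatic carbon. Among the measured compounds shown here, no measured pair isolates this change, so the step is judged from the structures alone. In this assay a step beyond the scatter towards a higher dose is expected for compound 3. Compound 3 is estimated at 2 mg/kg, between 0.4 mg/kg and 10 mg/kg. The expected step is a 4.0-fold higher number from compound 2 to compound 3 (0.60 log units; beyond the scatter).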

Compound 3, dose for 50% inhibition: > 10 mg/kg
Compound 3 was reported as a limit; the forecaster's own chance of this, stated with the estimate: 35%; middle value at least 5.0-fold (0.69 log units) from the limit.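

In this assay, isopropyl(methyl)sulfamoyl in place of chloro, para to an ethoxy group, gives an at least 20-fold higher number from compound 2 to compound 3 (1.30 log units; beyond the scatter). Among these compounds, this is the first single-place change, and it shows that the dose depends strongly on the group at this position. For compound 3 the read-out is a limit and not a number: the limit of > 10 mg/kg in this assay, at which 1 of the 3 values shown sits.

Open, from the compounds shown here alone, is whether the sulfonyl part or the isopropyl(methyl)amino part carries the loss. A plain sulfamoyl, a methylsulfonyl or a fluoro at this place would separate these and show whether any group other than chloro stays near compound 2 at 0.5 mg/kg.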